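The source may hold more compounds than are shown below. What is called first, only, known or untested is meant among the compounds shown, and "the series" means these compounds.

Measured compounds:
compound 1 `Cc1ccc2cccc(NS(=O)(=O)c3ccccc3[N+](=O)[O-])c2n1` — 8000 nM
compound 2 `Cc1ccc2cccc(NS(=O)(=O)c3ccccc3N)c2n1` — 8000 nM

In an assay on OCI-Ly3 cells for activation of NF-kappa-B inhibitor alpha (Homo sapiens), read by a luciferase reporter (a higher number here means that more compound is needed for the effect, a lower number that less compound is needed), compound 1 gives 8000 nM, and compound 2 gives 8000 nM. Compound 2 thus stands level with compound 1 at the digits shown; its nearest neighbour is compound 1, and the only measured step, no change at the digits printed from compound 1 to compound 2 (within the scatter), exchanges one substituent on the aryl ring attached to the sulfonyl sulfur without any change beyond the scatter.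

Compound 3 `Cc1ccc2cccc(NS(=O)(=O)c3ccc(Br)s3)c2n1` has not yet been measured. Its difference from compound 2 is 5-bromothiophen-2-yl in place of 2-aminophenyl on a sulfonyl sulfur. Within the data shown here, no measured step covers such an exchange of the whole ring on the sulfonyl sulfur; the one available step only shows that altering a substituent on that ring left this assay unmoved. On that thin basis, no step beyond the scatter is expected in either direction, though the uncertainty is wide. Compound 3 is therefore estimated at 8000 nM, with a range from 2500 nM to 25000 nM. This corresponds to an expected step of no change at the digits printed from compound 2 to compound 3 (within the scatter).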

Compound 3, half-maximal effective concentration: 6400 nM
For compound 3 the middle estimate is 1.3-fold (0.10 log units) above the measured one, within the range that was stated.
By their numbers in this assay, from the lowest: compounds 3, 1 and 2 (each within the scatter of the next).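

In this assay, the exchange of 2-aminophenyl for 5-bromothiophen-2-yl on the sulfonyl sulfur gives a 1.3-fold lower number from compound 2 to compound 3 (0.10 log units; within the scatter), so a measured step now covers replacement of the whole ring and not only of a substituent on it. The six-membered aromatic ring of carbon only gives way to a five-membered aromatic ring with a hetero atom, bromine enters, and the hydrogen-bond donor of the leaving group is lost, yet this combined change stays within the scatter in this one pair. No independent measurement is available to explain this result.

Since all the steps shown stay within the scatter, the compounds leave open what, if anything, at this position would move the number beyond it, for example a carboxylic acid on the aromatic ring or a simple alkyl chain such as n-butyl on the sulfonyl sulfur in place of the ring. The shared core is the same throughout, so they also leave open whether removing its methyl group or replacing it with a longer chain would matter.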